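The source may hold more compounds than are shown below. What is called first, only, known or untested is meant among the compounds shown, and "the series" means these compounds.

Measured so far, in a functional assay on MCF7 cells (Homo sapiens) for antiproliferative activity, read by MTT assay, with a stated time of 72 h; a higher number here means a weaker inhibitor, a lower number a stronger inhibitor:
compound 1 `CC(C)(C)c1cn(C[C@H](O)[C@H]2OC(=O)C(OCc3ccccc3)=C2OCc2ccccc2)nn1` gives 730 nM
compound 2 `O=C1O[C@H]([C@@H](O)Cn2cc(CNS(=O)(=O)c3ccc(F)cc3)nn2)C(OCc2ccccc2)=C1OCc1ccccc1` gives 26800 nM
compound 3 `C[Si](C)(C)c1cn(C[C@H](O)[C@H]2OC(=O)C(OCc3ccccc3)=C2OCc2ccccc2)nn1` gives 12100 nM

Compound 3 stands second highest of the three numbers, nearest to compound 2 and furthest from compound 1. The step of a 2.2-fold lower number from compound 2 to compound 3 (0.35 log units; beyond the scatter) is modest, while a 17-fold higher number from compound 1 to compound 3 (1.22 log units; beyond the scatter) is large. Compound 4 `Cc1ccc(-c2cn(C[C@H](O)[C@H]3OC(=O)C(OCc4ccccc4)=C3OCc3ccccc3)nn2)cc1` differs from compound 3 in one place: a group of 7 heavy atoms (7 carbon; one six-membered aromatic ring of carbon only) in place of a group of 4 heavy atoms (3 carbon, 1 silicon; no ring), on an aromatic carbon. For the measured compounds named here, no measured step swaps exactly this pair of groups, so the steps that bear on it are indirect. The step of a 17-fold higher number from compound 1 to compound 3 (1.22 log units; beyond the scatter) shows that changing the group on this aromatic carbon can move the number a long way, and a 37-fold higher number from compound 1 to compound 2 (1.56 log units; beyond the scatter) shows that the group carrying a six-membered aromatic ring gave the highest number of the three, whereas compound 1, with a group of no ring, holds the lowest. On these data the direction for compound 4 is uncertain, so only a moderate move downward is expected: a 3.0-fold lower number from compound 3 to compound 4 (0.48 log units; beyond the scatter). Compound 4 is therefore estimated at 4000 nM in this assay, with a range from 600 nM to 30000 nM.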

Compound 4, half-maximal inhibitory concentration: > 100000 nM
Compound 4 was reported as a limit; the forecaster's own chance of this, stated with the estimate: 5%; at least 25-fold (1.39 log units) between middle value and limit.
By their numbers in this assay, from the lowest: compound 1; then compound 3; then compound 2. At a limit, above all of these: compound 4.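

In this assay compound 4 gives a limit of the assay and not a number: the limit of > 100000 nM in this assay, at which 1 of the 4 values shown sits. Placing 4-methylphenyl on this aromatic carbon gives an at least 130-fold higher number from compound 1 to compound 4 (2.13 log units; beyond the scatter) against tert-butyl, an at least 8.2-fold higher number from compound 3 to compound 4 (0.91 log units; beyond the scatter) against the silicon-containing group, and an at least 3.7-fold higher number from compound 2 to compound 4 (0.57 log units; beyond the scatter) against (((4-fluorophenyl)sulfonyl)amino)methyl. Across these four compounds, the two whose group carries a six-membered aromatic ring, compound 2 and compound 4, now stand above the two without a ring, compound 1 and compound 3, and none goes against this, whereas one ring-bearing compound alone could not show it.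

The compounds shown leave open whether the ring or its methyl matters more, which a plain phenyl group on this carbon would help to separate. On these data alone, what a pyridine ring or a simple aminomethyl group would give here also remains open.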